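Inducible nitric oxide synthase series: cyclopropylcarbonyl to benzoyl step

The source may report more compounds than this note shows. Statements on the series, on what has been measured and on what is new or still open speak of the compounds shown alone.

Measured compounds and their values in an assay on isolated protein for inhibition of Nitric oxide synthase, inducible (Homo sapiens), with a stated time of 30 min, tested at 1 mM; a higher number here means more inhibition at the concentration tested (going by the name of the read-out), a lower number less inhibition:
Compound 1, `COc1cc(N)c(C2=NN(C(=O)C3CC3)CC2)cc1OC`: 25.2%
Compound 2, `COc1cc(N)c(C2=NN(C(=O)c3ccccc3)CC2)cc1OC`: 28.9%
Compound 3, `COc1cc(N)c(C2=NN(C(=O)C3CC3)CC2)c(OC)c1OC`: 30.1%

Working notes. Compound 3 gives the largest of the three numbers in this assay, but its distance to compound 2 and to compound 1 is within the scatter, so the three measured compounds read as one level rather than a ranking. The single-place steps confirm this: a number 3.7 percentage points higher from compound 1 to compound 2 (within the scatter) and a number 4.9 percentage points higher from compound 1 to compound 3 (within the scatter) both stay within the scatter.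

Compound 4, `COc1cc(N)c(C2=NN(C(=O)c3ccccc3)CC2)c(OC)c1OC`, is not yet measured in this assay. It differs from compound 3 in one place: phenyl in place of cyclopropyl on a carbonyl carbon. For the measured compounds named here, the only measured step of the same kind is the one from compound 1 to compound 2, which was a number 3.7 percentage points higher from compound 1 to compound 2 (within the scatter). On that basis the step expected in this assay from compound 3 to compound 4 is a number 2.9 percentage points higher from compound 3 to compound 4 (within the scatter), a shift that is not expected to exceed the scatter, if anything slightly upward. The estimate for compound 4 in this assay is therefore 33%, with a range from 22% to 44%, and the measurement will show whether the benzoyl change holds its small effect on this more methoxylated core.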

Compound 4, a percentage reported as inhibition, at one concentration (the size of the read-out at that concentration, not a potency): 8.14%
Compound 4: the middle estimate sits 24.9 percentage points above what was measured, outside the stated range (below it).
By their numbers in this assay, from the lowest: compound 4; then compounds 1, 2 and 3 (each within the scatter of the next).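

On the core of compound 3, phenyl in place of cyclopropyl on a carbonyl carbon gives a number 22 percentage points lower from compound 3 to compound 4 (beyond the scatter) in this assay, so the cyclopropylcarbonyl to benzoyl change does not carry over from one core to the other: the same change on two cores in this assay, a number 3.7 percentage points higher (within the scatter) from compound 1 to compound 2 and a number 22 percentage points lower (beyond the scatter) from compound 3 to compound 4, 25.7 percentage points apart, beyond the scatter of two such steps.
Read the other way, methoxy in place of hydrogen on an aromatic carbon gives a number 20.8 percentage points lower from compound 2 to compound 4 (beyond the scatter), so the effect of this methoxy also depends on which acyl group is present: the same change on two cores in this assay, a number 4.9 percentage points higher (within the scatter) from compound 1 to compound 3 and a number 20.8 percentage points lower (beyond the scatter) from compound 2 to compound 4, 25.7 percentage points apart, beyond the scatter of two such steps.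
The two changes therefore do not add up in these compounds: each alone stays within the scatter, and only their combination in compound 4 moves the number beyond it.

As far as these compounds go, with only cyclopropyl and phenyl on the carbonyl carbon, it remains open whether the loss on the more methoxylated core is specific to phenyl, and a longer chain or a carboxylic acid at that place on both cores would test this. From the compounds shown here alone, all these numbers also come from a single concentration, so how the compounds differ in potency remains open.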